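The source may hold more compounds than are shown below. What is called first, only, known or untested is meant among the compounds shown, and "the series" means these compounds.

Of the compounds shown here, two that share one core have been measured in an assay on isolated protein for inhibition of DNA topoisomerase 1 (Homo sapiens), with a stated time of 30 min, tested at 100 uM; on this read-out lower numbers stand for a weaker effect and higher numbers for a stronger effect at the one concentration tested. Compound 1 `Oc1ccc(-c2cc(-c3ccco3)cc(-c3cccc(O)c3)n2)cc1` gives 100% in this assay. For the measured compounds named here, compound 2 `Oc1cccc(-c2cc(-c3ccoc3)cc(-c3cccc(O)c3)n2)c1` gives 44.2% in this assay, the lower of the two numbers, and its only neighbour on this read-out, compound 1, stands higher by a margin well beyond the usual scatter. Compound 1 and compound 2 differ in two places at once, so their values show only that one arrangement of the three aryl groups reads high and the other reads lower.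

Compound 3 `Oc1ccc(-c2cc(-c3ccoc3)cc(-c3cccc(O)c3)n2)cc1` has not yet been measured. It differs from compound 2 by 4-hydroxyphenyl in place of 3-hydroxyphenyl on an aromatic carbon. Going by the values given here, the same 4-hydroxyphenyl group is present in compound 1, which gives 100%, while compound 3 keeps the furan-3-yl group of compound 2; no step for this change on its own is known. On that footing a rise from compound 2 is expected, though one that may fall short of compound 1. The expected step is a number 25.8 percentage points higher from compound 2 to compound 3 (beyond the scatter). Compound 3 is therefore estimated at 70%, with a range from 40% to 95%.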

Compound 3, a percentage reported as inhibition, at one concentration (the size of the read-out at that concentration, not a potency): 37.4%
Estimate against measurement, compound 3: 32.6 percentage points above; the whole stated range lies above it.
By their numbers in this assay, from the lowest: compounds 3 and 2 (each within the scatter of the next); then compound 1.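

In this assay, putting 4-hydroxyphenyl in place of 3-hydroxyphenyl on the aromatic carbon next to the ring nitrogen, with the furan-3-yl group kept, gives a number 6.8 percentage points lower from compound 2 to compound 3 (within the scatter), so with this furan the change at that position is not distinguishable from repeat scatter. The furan change alone, furan-3-yl in place of furan-2-yl with both hydroxyphenyl groups kept, gives a number 62.6 percentage points lower from compound 1 to compound 3 (beyond the scatter), a large step that the earlier pair could not isolate because two places differed at once. Among these three compounds, the high reading therefore goes with the furan-2-yl group and not with the hydroxyphenyl swap, and nothing at hand explains this difference.

It remains open whether the hydroxyphenyl swap would also make so little difference with furan-2-yl in place, since no pair shown tests that change on that background. Also open, going by these compounds, is how the reading would respond if an amine replaced the hydroxyl group on either phenyl ring, or if a thiophene ring replaced the furan.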